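Swapping Phenyl for Furan-2-yl on a Shared Nucleoside Core

The compounds below may be only part of what the source reports. "The series", "measured", "known", "first", "only" and "open" are said of these compounds alone.

In an ADME assay on BJ cells (Homo sapiens), read by MTT assay, with a stated time of 72 h (on this read-out lower numbers stand for stronger inhibition and higher numbers for weaker inhibition), compound 1 `CSc1ncnc2c1c(-c1ccccc1)cn2[C@@H]1O[C@H](CO)[C@@H](O)[C@H]1O` gives > 100000 nM, which is a limit of the assay rather than a number. Compound 2 `COc1ncnc2c1c(-c1ccccc1)cn2[C@@H]1O[C@H](CO)[C@@H](O)[C@H]1O` carries a methoxy in place of methylsulfanyl on an aromatic carbon of the shared core. In this assay compound 2 gives > 100000 nM, again a limit and not a measured number. The step between the two, a step that the two limits leave unreadable from compound 1 to compound 2, therefore cannot be read. Compound 2 thus stands at the edge of what this assay reports, and both values shown sit at that same edge, as the limit of > 100000 nM in this assay, at which 2 of the 2 values shown sit, records.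

Compound 3 `COc1ncnc2c1c(-c1ccco1)cn2[C@@H]1O[C@H](CO)[C@@H](O)[C@H]1O` differs from compound 2 in one place: furan-2-yl in place of phenyl on an aromatic carbon. Among the measured compounds shown here, the only measured step offers no readable size and no direction, so it gives no guidance for this change. With both known compounds at the limit, compound 3 is estimated at 100000 nM, with a range from 30000 nM to 300000 nM. The implied step, a number no higher from compound 2 to compound 3 (the limit leaves the size open), is expected to stay within the scatter, most likely ending once more in a limit rather than a number.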

Compound 3, half-maximal inhibitory concentration: 430 nM
Estimate against measurement, compound 3: 230-fold (2.37 log units) above; the measured number lies below the stated range.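

Before this result, the series had given no number to compare, only the same limit twice: the limit of > 100000 nM in this assay, at which 2 of the 3 values shown sit. In this assay, furan-2-yl in place of phenyl on an aromatic carbon brings an at least 230-fold lower number from compound 2 to compound 3 (2.36 log units; beyond the scatter), so this position, on the five-membered aromatic ring with 1 nitrogen, can decide whether a compound stays at the limit or gives a real number, and lower numbers here mean stronger inhibition. The change itself is small on paper, a five-membered aromatic ring with 1 hetero atom entering for a six-membered aromatic ring of carbon only, yet it is what separates compound 3 from compound 2, whose phenyl group left it at the limit.

This single pair cannot separate the ring size from the ring oxygen, and a group such as thiophen-2-yl or pyridin-2-yl at the same position would help tell the two apart. From the compounds shown here alone, it also remains open whether methylsulfanyl in place of methoxy on the furan-2-yl compound would keep a measurable number, and whether an amine at that spot would do the same.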